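The source may hold more compounds than are shown below. What is called first, only, known or untested is meant among the compounds shown, and "the series" means these compounds.

Measured in a functional assay on MCF7 cells (Homo sapiens) for antiproliferative activity, read by MTT assay, with a stated time of 96 h; on this read-out higher numbers stand for weaker inhibition and lower numbers for stronger inhibition:

Compound 1 `COc1ccc(N2C(=O)NC3(CSC4=C3C(=O)c3ncccc3C4=O)C2=O)cc1` gives 50 nM
Compound 2 `O=C1C2=C(C(=O)c3ncccc31)C1(CS2)NC(=O)N(c2ccccc2)C1=O` gives 1 nM
Compound 3 `Cc1ccc(N2NC(=O)NC3(CSC4=C3C(=O)c3ncccc3C4=O)C2=O)cc1` gives 410 nM

Compound 2 has the lowest number of the three in this assay. Its nearest neighbour is compound 1, and the step of a 50-fold lower number from compound 1 to compound 2 (1.70 log units; beyond the scatter) lies beyond the scatter. Among the compounds with values here, compound 3 stands furthest away; no single-point step links it to compound 2, but its value is far higher than that of compound 2.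

Compound 4 `CC(C)(C)c1ccc(N2C(=O)NC3(CSC4=C3C(=O)c3ncccc3C4=O)C2=O)cc1` has not yet been measured. It differs from compound 2 in one place: tert-butyl in place of hydrogen on an aromatic carbon.

Within the data shown here, only one measured step bears on this change, the one from compound 1 to compound 2, in which a methoxy group was removed from the same aromatic carbon and the number fell by a large amount. Compound 4 reverses that direction by adding a tert-butyl group at that carbon. Compound 4 is therefore expected to give a higher number than compound 2 in this assay, with a step of roughly a 100-fold higher number from compound 2 to compound 4 (2.00 log units; beyond the scatter) expected. The estimate for compound 4 is 100 nM, with a range from 10 nM to 1000 nM.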

Compound 4, half-maximal inhibitory concentration: 130 nM
Estimate against measurement, compound 4: 1.3-fold (0.11 log units) below, within the range that was stated.
By their numbers in this assay, from the lowest: compound 2; then compound 1; then compound 4; then compound 3.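

At the aromatic carbon para to a large group, a second substituent now points the same way as the first in this assay, with a 130-fold higher number from compound 2 to compound 4 (2.11 log units; beyond the scatter), matching the reverse of a 50-fold lower number from compound 1 to compound 2 (1.70 log units; beyond the scatter), so among compound 1, compound 2 and compound 4 the unsubstituted phenyl has the lowest number and none of the three goes against this. The two groups are not interchangeable, though the gap between them is much smaller than the gap between either of them and hydrogen, with a 2.6-fold higher number from compound 1 to compound 4 (0.41 log units; beyond the scatter), a modest step that still lies beyond the scatter. Nothing measured here accounts for these differences at this carbon.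

Across these three compounds the position has carried only hydrogen, methoxy and tert-butyl, so it remains open whether a fluorine atom, a methyl group, an amine or a carboxylic acid at this carbon would stay close to compound 2 or move towards compound 1 and compound 4. On these data alone, it is also open how methoxy or tert-butyl would behave on the other carbons of this aromatic ring.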